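This account rests on a few compounds, and the source may have more. Where it says the series, first, only, none or still open, it means among the compounds named here.

Compound 1, `O=C(/C=C\c1ccc(O)cc1)N1N=C(c2ccncc2)OC1c1c[nH]c2ccccc12`: in an ADME assay on PANC-1 cells (Homo sapiens) for cytotoxicity, read by MTT assay, with a stated time of 48 h (on this read-out lower numbers stand for stronger inhibition of growth and higher numbers for weaker inhibition of growth), compound 1 gives > 30 ug/mL, which is a limit of the assay and not a number.
Compound 2, `O=C(/C=C\c1ccccc1[N+](=O)[O-])N1N=C(c2ccncc2)OC1c1c[nH]c2ccccc12`: in this assay compound 2 gives > 30 ug/mL, again a limit.
Compound 3, `O=C(/C=C\c1ccc(F)cc1)N1N=C(c2ccncc2)OC1c1c[nH]c2ccccc12`: in this assay compound 3 gives > 30 ug/mL, also a limit.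

Compound 3 therefore stands where the other two stand, at the limit of > 30 ug/mL in this assay, at which 3 of the 3 values shown sit. For that reason none of the measured steps carries a readable size: a step that the two limits leave unreadable from compound 1 to compound 2, a step that the two limits leave unreadable from compound 1 to compound 3 and a step that the two limits leave unreadable from compound 2 to compound 3. Compound 4, `O=C(/C=C/c1c(Cl)cccc1Cl)N1N=C(c2ccncc2)OC1c1c[nH]c2ccccc12`, differs from compound 3 by 2-(2,6-dichlorophenyl)ethenyl in place of 2-(4-fluorophenyl)ethenyl on a carbonyl carbon. Within the data shown here, the steps that bear on this change are the three exchanges of the aryl group on the ethenyl chain, and all of them are hidden by the limit, so they give no direction and no size. On this basis no step beyond the scatter is expected; the expected step is a step that the limit leaves unreadable from compound 3 to compound 4. Compound 4 is estimated at 35 ug/mL in this assay, with a range from 12 ug/mL to 100 ug/mL, and most likely it too will be reported only as a limit.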

Compound 4, concentration for 50% growth inhibition: > 30 ug/mL
Compound 4 ended at the assay's limit (the forecaster's own chance of this, stated with the estimate: 70%); the middle value is on the limit's open side.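

Compound 4 also gives a limit of the assay and not a number, so its steps from compound 1, compound 2 and compound 3 cannot be read: the limit of > 30 ug/mL in this assay, at which 4 of the 4 values shown sit.

The compounds shown leave open whether exchanging the aryl group on the ethenyl chain changes growth inhibition at all, and in which direction.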